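Swapping Fluoro for Isopropyl: Expected Permeability of Compound 3

The source may report more compounds than this note shows. Statements on the series, on what has been measured and on what is new or still open speak of the compounds shown alone.

Compound 1, `CNC(=O)c1cc(Oc2ccc3nc(Nc4ccccc4Br)ncc3c2)ccn1`: in an ADME assay on Caco-2 cells (Homo sapiens) for permeability, in the apical to basolateral direction (a higher number here means that the compound crosses the layer faster, a lower number that the compound crosses the layer more slowly), compound 1 gives < 1 10^-6 cm/s, which is a limit of the assay rather than a number.
Compound 2, `CNC(=O)c1cc(Oc2ccc3nc(Nc4ccc(F)cc4)ncc3c2)ccn1`: in this assay compound 2 gives < 1 10^-6 cm/s, again a limit of the assay.

Both measured values sit at the limit of < 1 10^-6 cm/s in this assay, at which 2 of the 2 values shown sit, so the step that the two limits leave unreadable from compound 1 to compound 2 cannot be read in either direction or size. Compound 2 therefore stands at a limit only: its permeability is known to be low, but not how low. Compound 3, `CNC(=O)c1cc(Oc2ccc3nc(Nc4ccc(C(C)C)cc4)ncc3c2)ccn1`, differs from compound 2 in one place: isopropyl in place of fluoro on an aromatic carbon. Among the measured compounds shown here, no measured step touches this change, and the single step that is known is itself unreadable, so it gives no guide to the size or direction of the step to compound 3. The expectation must rest on where compound 2 stands, at a limit, with nothing showing that a change on this ring moves the value beyond it. In this assay the step to compound 3 is expected to be an at least 1.2-fold higher number from compound 2 to compound 3 (0.07 log units; that floor lies within the scatter), with a fair chance that the assay again returns only a limit. Compound 3 is estimated at 1.2 10^-6 cm/s, in the range 0.3 10^-6 cm/s to 5 10^-6 cm/s.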

Compound 3, apparent permeability: < 1 10^-6 cm/s
Compound 3 gave a limit, no number; the forecaster's own chance of this, stated with the estimate: 45%; middle value at least 1.2-fold (0.07 log units) away from the limit.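

Compound 3 also gives a limit of the assay rather than a number, so its steps from compound 1 and compound 2 cannot be read in size or direction: the limit of < 1 10^-6 cm/s in this assay, at which 3 of the 3 values shown sit.

The compounds shown leave open how compound 1, compound 2 and compound 3 truly differ in this assay, and whether any change at this place gives a readable number.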